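Replacing cyano with 1,2,4-oxadiazol-3-yl on the ether side chain

This account rests on a few compounds, and the source may have more. Where it says the series, first, only, none or still open, it means among the compounds named here.

In an in vitro ADME assay on microsomes from liver (Homo sapiens) for metabolic stability (a lower number here means that the compound disappears faster, a higher number that the compound lasts longer), three compounds have been tested so far, and none has given a plain number. Compound 1 (`CCOc1cccc2c1S(=O)(=O)N=C2C1=C(O)[C@H](C(C)(C)C)N(CCC(C)(C)C)C1=O`) reports > 1 h as a limit of the assay, not a number. Compound 2 (`CC(C)(C)[C@H]1C(O)=C(C2=NS(=O)(=O)c3c(OCC(N)=O)cccc32)C(=O)N1Cc1ccc(F)c(Cl)c1`) gives > 1 h as a limit too. Compound 3 (`CC(C)(C)[C@H]1C(O)=C(C2=NS(=O)(=O)c3c(OCC#N)cccc32)C(=O)N1Cc1ccc(F)c(Cl)c1`) gives > 1 h as a limit as well, so its true half-life is not known. The shared position is the limit of > 1 h in this assay, at which 3 of the 3 values shown sit, and offers no ranking.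

The next compound is compound 4 (`CC(C)(C)[C@H]1C(O)=C(C2=NS(=O)(=O)c3c(OCc4ncon4)cccc32)C(=O)N1Cc1ccc(F)c(Cl)c1`), which has 1,2,4-oxadiazol-3-yl in place of cyano on a saturated chain carbon bound to an oxygen on an aromatic ring. For the measured compounds named here, the one measured step at this place is a step that the two limits leave unreadable from compound 2 to compound 3 with cyano in place of carbamoyl. The size of that step cannot be read, and the limit of > 1 h in this assay, at which 3 of the 3 values shown sit, is all that compound 1, compound 2 and compound 3 offer, so no step beyond the scatter is expected in this assay in either direction. The estimated change is a step that the limit leaves unreadable from compound 3 to compound 4 and may stay hidden behind a limit. For compound 4 the estimate is 1.5 h with a range from 0.7 h to 4 h and a good chance of only a limit.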

Compound 4, half-life: > 1 h
Compound 4 ended at the assay's limit; the forecaster's own chance of this, stated with the estimate: 70%; the middle value does not contradict the limit.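

Compound 4 adds no readable step against compound 2 or compound 3 in this assay, and all of these results are limits rather than numbers: the limit of > 1 h in this assay, at which 4 of the 4 values shown sit.

The compounds shown leave open the true half-life of each compound in this assay, and whether 1,2,4-oxadiazol-3-yl, cyano and carbamoyl differ at all at this place.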